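The source may hold more compounds than are shown below. What is called first, only, known or untested is meant among the compounds shown, and "the series" means these compounds.

In a functional assay on HT cells (Homo sapiens) for antiproliferative activity, read by fluorescence, with a stated time of 72 h (a lower number here means a stronger inhibitor of growth, a higher number a weaker inhibitor of growth), three compounds sharing one core have been measured. Compound 1 `CC(C)c1n[nH]c2c(NCc3ccc(-c4ccccn4)cc3)nc(SCCN)nc12` gives 22 nM, compound 2 `CC(C)c1n[nH]c2c(NCc3ccc(-c4ccccn4)cc3)nc(SCCNC(N)=O)nc12` gives 240 nM and compound 3 `CC(=O)NCCSc1nc(NCc2ccc(-c3ccccn3)cc2)c2[nH]nc(C(C)C)c2n1` gives 71 nM, so compound 3 holds the second highest of the three numbers. Compound 4 `CC(C)c1n[nH]c2c(NCc3ccc(-c4ccccn4)cc3)nc(SC3CCCCC3N)nc12` has 2-aminocyclohexyl in place of 2-acetamidoethyl on a sulfur. For the measured compounds named here, two measured steps bear most directly on this change. Acetyl in place of hydrogen on an amine nitrogen gave a 3.2-fold higher number from compound 1 to compound 3 (0.51 log units; beyond the scatter), and carbamoyl in place of hydrogen on an amine nitrogen gave an 11-fold higher number from compound 1 to compound 2 (1.04 log units; beyond the scatter). The two capped compounds are themselves separated by a 3.4-fold lower number from compound 2 to compound 3 (0.53 log units; beyond the scatter). Going by the values given here, compound 4, like compound 1, has no such group on its amine nitrogen, but no measured compound carries a ring on that sulfur, so the size of the step remains uncertain. A modest move to a lower number is expected, an estimated 2.4-fold lower number from compound 3 to compound 4 (0.37 log units; beyond the scatter). In this assay, compound 4 is expected at an estimated 30 nM, within a range of 9 nM to 100 nM.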

Compound 4, concentration for 50% growth inhibition: 139 nM
For compound 4 the middle estimate is 4.6-fold (0.67 log units) below the measured one; measured number above the stated range.
By their numbers in this assay, from the lowest: compound 1; then compounds 3, 4 and 2 (each within the scatter of the next, the first and the last beyond it).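

In this assay, an uncapped amine nitrogen on the group attached to sulfur does not by itself preserve the low number of compound 1, since 2-aminocyclohexyl in place of 2-aminoethyl gives a clear step (a 6.3-fold higher number from compound 1 to compound 4 (0.80 log units; beyond the scatter)). Compound 4 instead stands level with the two capped compounds (a 2.0-fold higher number from compound 3 to compound 4 (0.29 log units; within the scatter); a 1.7-fold lower number from compound 2 to compound 4 (0.24 log units; within the scatter)). The carbon framework on the sulfur therefore matters in this series, alongside the capping of the amine nitrogen, and the data offered no evidence to explain this result.

The compounds shown leave open whether the six-membered ring itself or the carbon framework more generally accounts for this step. They also leave open how a plain cyclohexyl without the amine, a longer chain ending in an amine, or a branched open-chain amine would read.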